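The source may report more compounds than this note shows. Statements on the series, on what has been measured and on what is new or still open speak of the compounds shown alone.

In a functional assay on HepG2 cells (Homo sapiens) for antiproliferative activity, read by MTT assay (on this read-out higher numbers stand for weaker inhibition and lower numbers for stronger inhibition), compound 1 `Cc1c(-n2cc(COc3ccc(/C=C/C(=O)c4cc5c(cc4O)OC(C)(C)CC5)cc3)nn2)cccc1[N+](=O)[O-]` gives 109000 nM. Compound 2 `Cc1c(-n2cc(COc3ccc(/C=C/C(=O)c4ccc5c(c4O)CCC(C)(C)O5)cc3)nn2)cccc1[N+](=O)[O-]` gives 115000 nM, and compound 3 `CC(=O)c1ccc(-n2cc(COc3ccc(/C=C/C(=O)c4ccc5c(c4O)CCC(C)(C)O5)cc3)nn2)cc1` gives 91400 nM. These three numbers all lie within the scatter of one another, so compound 1 has no separate standing among them.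

Compound 4 `CCCCCCCCn1cc(COc2ccc(/C=C/C(=O)c3cc4c(cc3O)OC(C)(C)CC4)cc2)nn1` differs from compound 1 as follows: octyl in place of 2-methyl-3-nitrophenyl on an aromatic nitrogen. In words, this is octyl in place of 2-methyl-3-nitrophenyl on an aromatic nitrogen.

For the measured compounds named here, only one measured step bears on this change: a 1.3-fold lower number from compound 2 to compound 3 (0.10 log units; within the scatter). It also replaces the group on an aromatic nitrogen, but it exchanges one substituted phenyl for another and stays within the scatter. Going by the values given here, no measured compound carries an open chain such as octyl, so the series gives no direct measure of this replacement, and the range must be kept wide. No shift beyond the scatter is expected in this assay, in either direction. The estimated step is a 1.2-fold lower number from compound 1 to compound 4 (0.08 log units; within the scatter). Compound 4 is expected at 90000 nM, with an estimated range of 35000 nM to 180000 nM.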

Compound 4, half-maximal inhibitory concentration: 127000 nM
Estimate against measurement, compound 4: 1.4-fold (0.15 log units) below; the measured number falls inside the stated range.
By their numbers in this assay, from the lowest: compounds 3, 1, 2 and 4 (each within the scatter of the next).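

In this assay, the step to the open chain is a 1.2-fold higher number from compound 1 to compound 4 (0.07 log units; within the scatter): on this aromatic nitrogen, octyl takes the place of 2-methyl-3-nitrophenyl with no shift beyond the scatter. The earlier step at this position only exchanged one substituted phenyl for another, whereas this one removes the six-membered aromatic ring and the hydrogen-bond acceptors of the leaving group, and the reading still does not move beyond the scatter. No measurement on hand accounts for this lack of response.

Going by these compounds, whether an amine or a carboxylic acid on this aromatic nitrogen, or a chain shorter than octyl, would give a step beyond the scatter remains open. Also open, on these data alone, is whether octyl would behave the same way on the core of compound 2.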